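The source may report more compounds than this note shows. Statements on the series, on what has been measured and on what is new or still open speak of the compounds shown alone.

Of the compounds shown here, three that share one core have been tested in an ADME assay on THP-1 cells (Homo sapiens) for cytotoxicity; a lower number here means that less compound is tolerated, a higher number that more compound is tolerated. Compound 1 `CN(C)CCNc1c(-c2ccccn2)nc2ccccn12` carries a (dimethylamino)methyl group on a saturated chain carbon bound to a nitrogen on an aromatic ring. In this assay compound 1 gives > 50000 nM, which is a limit of the assay and not a number. Compound 2 `c1ccc(-c2nc3ccccn3c2NCC2CCO2)nc1` carries oxetan-2-yl on that carbon instead. In this assay compound 2 gives > 50000 nM, again a limit. Compound 3 `c1ccc(CNc2c(-c3ccccn3)nc3ccccn23)cc1` carries phenyl on that carbon. In this assay compound 3 gives > 50000 nM, also a limit. Compound 3 therefore stands at the limit of > 50000 nM in this assay, at which 3 of the 3 values shown sit, and none of the three can be ranked against the others. Each measured step, a step that the two limits leave unreadable from compound 1 to compound 2, a step that the two limits leave unreadable from compound 1 to compound 3 and a step that the two limits leave unreadable from compound 2 to compound 3, is hidden in the same way.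

Compound 4 `N#Cc1ccc(Nc2c(-c3ccccn3)nc3ccccn23)cc1` is the next member. The change is 4-cyanophenyl in place of benzyl on a nitrogen on an aromatic ring, so the whole group on that nitrogen is exchanged rather than only its end. For the measured compounds named here, no measured step offers a readable size, so the expectation rests on the shared limit alone. The expected step of a number no higher from compound 3 to compound 4 (the limit leaves the size open) is none beyond the scatter. Compound 4 is estimated at 50000 nM, with a range from 20000 nM to 150000 nM, most likely again reported only as a limit.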

Compound 4, half-maximal cytotoxic concentration: > 50000 nM
Compound 4: only a limit was reported; the forecaster's own chance of this, stated with the estimate: 75%; the middle value sits exactly at the limit.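

In this assay compound 4 gives > 50000 nM, which is a limit and not a number. The steps to compound 4 from compound 1, compound 2 and compound 3 therefore cannot be read, and all four compounds stand together: the limit of > 50000 nM in this assay, at which 4 of the 4 values shown sit. The compounds shown leave open the actual half-maximal cytotoxic concentration of each compound, and whether exchanging the group on the nitrogen changes it at all.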